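The source may hold more compounds than are shown below. What is called first, only, known or untested is meant among the compounds shown, and "the series" means these compounds.

Measured so far in an in vitro ADME assay on microsomes from liver (Mus musculus) for pharmacokinetics, read by LC-MS, with a stated time of 10 min, tested at 1 uM; on this read-out higher numbers stand for fast clearance and lower numbers for slow clearance:
- compound 1 `COc1cccc(NC(=O)[C@H]2CN(C)C[C@@H]2c2ccc(/C=C/C(=O)Nc3ccccc3N)cc2)c1` gives 65 mL/min/kg
- compound 2 `CN1C[C@H](C(=O)Nc2ccc(F)c(Br)c2)[C@@H](c2ccc(/C=C/C(=O)Nc3ccccc3N)cc2)C1` gives 43 mL/min/kg

Compound 2 at 43 mL/min/kg stands within the scatter of compound 1 at 65 mL/min/kg. Compound 3 `CN1C[C@H](C(=O)Nc2ccc(Cl)cn2)[C@@H](c2ccc(/C=C/C(=O)Nc3ccccc3N)cc2)C1` carries 5-chloropyridin-2-yl in place of 3-bromo-4-fluorophenyl on an amide-type nitrogen. Within the data shown here, one measured step bears on this place (a 1.5-fold lower number from compound 1 to compound 2 (0.18 log units; within the scatter)), and no measured compound has a hetero atom in that ring. On that single step, no change beyond the scatter is expected in this assay. The estimated step is a 1.2-fold higher number from compound 2 to compound 3 (0.07 log units; within the scatter), with no firm direction. The estimate for compound 3 is 50 mL/min/kg (expected range 27 mL/min/kg to 90 mL/min/kg).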

Compound 3, clearance: 31 mL/min/kg
Beside the measured number, compound 3's estimate is 1.6-fold (0.21 log units) above it; the range from low to high includes it.
By their numbers in this assay, from the lowest: compounds 3, 2 and 1 (each within the scatter of the next, the first and the last beyond it).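

In this assay a ring with a hetero atom now appears on the amide-type nitrogen: 5-chloropyridin-2-yl in place of 3-bromo-4-fluorophenyl gives a 1.4-fold lower number from compound 2 to compound 3 (0.14 log units; within the scatter) and does not separate these two groups. Among these compounds, in place of 3-methoxyphenyl, the same group gives a 2.1-fold lower number from compound 1 to compound 3 (0.32 log units; beyond the scatter) as the first step at this place to lie beyond the scatter, though only modestly. No evidence is at hand to explain either step.

On these data alone, whether this step follows the ring nitrogen or the chlorine stays open, as the two enter together. Also open, as far as these compounds go, is how this place reads with unsubstituted pyridin-2-yl or with a carboxylic acid on the ring.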